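The compounds below may be only part of what the source reports. "The series", "measured", "known", "first", "only" and "open" are said of these compounds alone.

Compound 1 `OC[C@H]1O[C@@H](n2cnc3c(SCc4cccc(Cl)c4)ncnc32)[C@H](O)[C@@H]1O`: 18.2 nM in an assay on isolated protein for inhibition of Equilibrative nucleoside transporter 1 (Homo sapiens); a higher number here means a weaker inhibitor, a lower number a stronger inhibitor
Compound 2 `N#Cc1ccccc1CSc1ncnc2c1ncn2[C@@H]1O[C@H](CO)[C@@H](O)[C@H]1O`: 38.9 nM in this assay

For the measured compounds named here, compound 2 stands at the higher of the two numbers so far, set apart from its only neighbour by a 2.1-fold higher number from compound 1 to compound 2 (0.33 log units; beyond the scatter), a modest step that lies beyond the scatter. Compound 3 `N#Cc1ccc(CSc2ncnc3c2ncn3[C@@H]2O[C@H](CO)[C@@H](O)[C@H]2O)cc1` is made from compound 2 by 4-cyanophenyl in place of 2-cyanophenyl on a saturated chain carbon bound to a sulfur. Going by the values given here, no measured pair compares two placements of the same substituent on that ring, so the change has no direct precedent. Among the compounds with values here, the one step that bears on it at all, a 2.1-fold higher number from compound 1 to compound 2 (0.33 log units; beyond the scatter), exchanged both the group and its placement and was itself modest, which suggests that such changes on this benzyl sulfide do not move this assay far. The expectation is therefore a step of at most similar size, in either direction, and most likely none beyond the scatter, a 1.1-fold lower number from compound 2 to compound 3 (0.05 log units; within the scatter). Compound 3 is accordingly estimated at 35 nM, with a range from 12 nM to 100 nM, the width reflecting that the placement effect itself is unmeasured.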

Compound 3, inhibition constant: 4.57 nM
For compound 3 the middle estimate is 7.7-fold (0.88 log units) above the measured one; measured number outside the range, below it.
By their numbers in this assay, from the lowest: compound 3; then compound 1; then compound 2.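

Moving the nitrile alone, from 2-cyanophenyl to 4-cyanophenyl on a saturated chain carbon bound to a sulfur, gives an 8.5-fold lower number from compound 2 to compound 3 (0.93 log units; beyond the scatter) in this assay. With the atoms unchanged, placement on this ring therefore matters in its own right, and this step is larger than the earlier one, in which both the group and its placement changed. The exchange of 3-chlorophenyl for 4-cyanophenyl gives a 4.0-fold lower number from compound 1 to compound 3 (0.60 log units; beyond the scatter), which makes the 4-cyanophenyl compound the strongest inhibitor of the three, while no measurement given here accounts for the effect of placement.

From the compounds shown here alone, it remains open whether the order seen for 2-cyanophenyl and 4-cyanophenyl carries over to other groups on the ring, such as a carboxylic acid or an amine in place of the nitrile. It is also unresolved whether a longer chain on the sulfur would preserve the low number reached with the 4-cyanobenzyl group, or whether the effect of placement depends on the single chain carbon present in all the compounds shown.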